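Benzyl in Place of 4-Aminophenyl: What to Expect

The source may hold more compounds than are shown below. What is called first, only, known or untested is meant among the compounds shown, and "the series" means these compounds.

Among the measured compounds shown here, compound 3 `Nc1ccc(Nc2c(C(=O)NCc3ccc(F)cc3)nc(Br)c3cccnc23)cc1` is the only member of this small set with an actual number: in a functional assay on MDA-MB-435 cells (Homo sapiens) for cytotoxicity, read by MTT assay, with a stated time of 72 h (on this read-out lower numbers stand for stronger inhibition and higher numbers for weaker inhibition), compound 3 gives 7000 nM. Compound 1 `O=C(NCc1ccc(F)cc1)c1nc(NCCO)c2cccnc2c1O` is reported only as a limit of the assay, > 20000 nM. Compound 2 `O=C(NCc1ccc(F)cc1)c1nc(Br)c2cccnc2c1NCCCNc1c(C(=O)NCc2ccc(F)cc2)nc(Br)c2cccnc12` likewise reaches only the limit > 20000 nM. Two of the three results thus sit at that boundary (the limit of > 20000 nM in this assay, at which 2 of the 3 values shown sit). Compound 3 therefore stands alone as the single measurable point. Compound 4 `O=C(NCc1ccc(F)cc1)c1nc(Br)c2cccnc2c1NCc1ccccc1` differs from compound 3 in one place: benzyl in place of 4-aminophenyl on a nitrogen on an aromatic ring. For the measured compounds named here, no comparable step between measured compounds exists, so the direction cannot be read from these data. A change of about a 1.4-fold higher number from compound 3 to compound 4 (0.15 log units; within the scatter) is expected, within the usual scatter or a slight loss. Compound 4 is estimated at 10000 nM, between 3000 nM and 30000 nM.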

Compound 4, half-maximal inhibitory concentration: > 20000 nM
Compound 4: only a limit was reported; the forecaster's own chance of this, stated with the estimate: 35%; middle value at least 2.0-fold (0.30 log units) from the limit.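

Swapping 4-aminophenyl for benzyl on this nitrogen gives the first readable step in the set, an at least 2.8-fold higher number from compound 3 to compound 4 (0.45 log units; beyond the scatter) in this assay. For compound 4 the value > 20000 nM is a limit of the assay, not a number, so the step gives only a smallest size. The two groups have the same number of heavy atoms and the same kind of ring, so matching those two features did not keep the activity of compound 3.

On these data alone, it remains open whether the amino group or the direct link from ring to nitrogen matters, which plain phenyl on this nitrogen could separate. Further comparison is also restricted: the limit of > 20000 nM in this assay, at which 3 of the 4 values shown sit.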